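Adenine riboside hydrazones: aryl in place of a dienyl chain

The source may hold more compounds than are shown below. What is called first, only, known or untested is meant among the compounds shown, and "the series" means these compounds.

Measured so far:
compound 1 `CCCCC/C=C/C=C/C=N/Nc1nc(N)c2ncn([C@@H]3O[C@H](CO)[C@@H](O)[C@H]3O)c2n1` 2 nM
compound 2 `CC(/C=N/Nc1nc(N)c2ncn([C@@H]3O[C@H](CO)[C@@H](O)[C@H]3O)c2n1)Cc1ccc(C(C)C)cc1` 9500 nM
compound 3 `Nc1nc(N/N=C/c2ccc(OCc3ccccc3)c(OCc3ccccc3)c2)nc2c1ncn2[C@@H]1O[C@H](CO)[C@@H](O)[C@H]1O` > 10000 nM, a limit of the assay

In an assay on CHO-K1 cells for displacement of a labelled ligand from adenosine receptor A1 (Homo sapiens), read by scintillation counting, with a stated time of 60 min (on this read-out lower numbers stand for stronger inhibition and higher numbers for weaker inhibition), compound 1 stands lowest of the two numbers shown; the nearest is compound 2, whose value is beyond the scatter and far weaker. Compound 3 reports only a limit of this assay the limit of > 10000 nM in this assay, at which 1 of the 3 values shown sits, and gives no number.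

Compound 4 `Nc1nc(N/N=C/c2ccc(Cl)c(C(F)(F)F)c2)nc2c1ncn2[C@@H]1O[C@H](CO)[C@@H](O)[C@H]1O` differs from compound 1 in one place: a group of 11 heavy atoms (7 carbon, 3 fluorine, 1 chlorine; one six-membered aromatic ring of carbon only) in place of a group of 9 heavy atoms (9 carbon; no ring), on a carbon with a double bond to nitrogen. The change exchanges the dienyl chain of compound 1 for an aryl ring. Compound 3, the other aryl hydrazone, sits at the limit, and compound 2, with a ring in its chain, is also weak; on this basis a large loss is expected from compound 1 to compound 4, a 1500-fold higher number from compound 1 to compound 4 (3.18 log units; beyond the scatter). Compound 4 is therefore estimated at 3000 nM in this assay, with a range from 300 nM to 20000 nM, and a fair chance that only a limit is reported.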

Compound 4, inhibition constant: > 10000 nM
Compound 4: only a limit was reported; the forecaster's own chance of this, stated with the estimate: 30%; middle value at least 3.3-fold (0.52 log units) from the limit.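

In this assay, replacing the dienyl chain on the carbon with a double bond to nitrogen by 4-chloro-3-(trifluoromethyl)phenyl gives an at least 5000-fold higher number from compound 1 to compound 4 (3.69 log units; beyond the scatter), the only single change shown at this place. The value of compound 4 is a limit of the assay, so this step sets a minimum for the loss and does not give its full size. Compound 3 and compound 4, both with an aryl ring at this place, give no number on this read-out: the limit of > 10000 nM in this assay, at which 2 of the 4 values shown sit.

The compounds shown do not separate the effect of the ring itself from that of the groups it carries, a question that an unsubstituted phenyl or a ring bearing an amine or a carboxylic acid would address. On these data alone, how much of the dienyl chain is needed also stays open, and a saturated alkyl chain or a shorter dienyl chain at the same place would test this.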